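Series notes: oxetan-3-yl to 2-methoxyethyl

A few compounds are considered here, and "the series" means these few. Any claim that something is new, unique, unknown or untested is made for them only; others in the source may bear on it.

For the measured compounds named here, in a physicochemical assay for lipophilicity, read by HPLC, at pH 7.4 (a lower number here means a more polar compound, a higher number a more lipophilic compound), compound 2 `Cc1ccccc1N1C(=O)/C(=C/c2ccc(O)c(Cl)c2)S/C1=N\C1COC1` stands at 2.6 as the lower of the two numbers so far, and compound 1 `Cc1ccccc1N1C(=O)/C(=C/c2ccc(O)c(Cl)c2)S/C1=N\CCCF` stands at 3.4 above it. Compound 3 `COCC/N=C1\S/C(=C\c2ccc(O)c(Cl)c2)C(=O)N1c1ccccc1C` has 2-methoxyethyl in place of oxetan-3-yl on a double-bonded nitrogen. Going by the values given here, only one measured step bears on this place: the modest drop a number 0.80 log units lower from compound 1 to compound 2 (beyond the scatter), which lies beyond the scatter and came with oxetan-3-yl in place of 3-fluoropropyl. Compound 3 resembles compound 1 in having an open chain there, but the chain is a different one, so only part of that drop is expected to return. The expected rise in this assay is a number 0.40 log units higher from compound 2 to compound 3 (beyond the scatter) and is smaller than that drop. The estimated value for compound 3 is 3 (expected range 2.6 to 3.4).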

Compound 3, distribution coefficient: 2.9
Compound 3: the middle estimate sits 0.10 log units above what was measured, within the range that was stated.
By their numbers in this assay, from the lowest: compounds 2 and 3 (each within the scatter of the next); then compound 1.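

In this assay the exchange of oxetan-3-yl for 2-methoxyethyl on a double-bonded nitrogen gives a number 0.30 log units higher from compound 2 to compound 3 (within the scatter) and so does not separate the ring from the open chain at this place, each group having 4 heavy atoms and 1 hydrogen-bond acceptor. Methoxy in place of fluoromethyl on the saturated chain gives a number 0.50 log units lower from compound 1 to compound 3 (beyond the scatter) and shows that an open chain alone does not return the number of compound 1, so the earlier step of a number 0.80 log units lower from compound 1 to compound 2 (beyond the scatter) cannot be read as ring against chain alone. Nothing at hand explains either step.

Still open, going by these compounds, is how this assay responds at this place to an amine or a carboxylic acid. Also open, on these data alone, is whether a longer chain carrying the methoxy group would stay within the scatter of compound 3 or move towards compound 1.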